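Butylamino in place of octyloxy: from compound 2 to compound 3

A few compounds are considered here, and "the series" means these few. Any claim that something is new, unique, unknown or untested is made for them only; others in the source may bear on it.

Among the measured compounds shown here, compound 1 (`CC(C)(C)c1ccc(C(=O)N/N=C/c2ccc([N+](=O)[O-])o2)cc1`) and compound 2 (`CCCCCCCCOc1ccc(C(=O)N/N=C/c2ccc([N+](=O)[O-])o2)cc1`) are the two measured members in an ADME assay on U2OS cells (Homo sapiens) for cytotoxicity; a higher number here means that more compound is tolerated, a lower number that less compound is tolerated. Compound 1 gives > 200000 nM, which is a limit. Compound 2 gives > 200000 nM, also a limit and not a number. Compound 3 (`CCCCNc1ccc(C(=O)N/N=C/c2ccc([N+](=O)[O-])o2)cc1`) has butylamino in place of octyloxy on an aromatic carbon. For the measured compounds named here, the only measured step bearing on this change is a step that the two limits leave unreadable from compound 1 to compound 2, so its size cannot be read. No step beyond the scatter, in either direction, is expected in this assay. The expected step is a number no higher from compound 2 to compound 3 (the limit leaves the size open). For compound 3 the estimate is 200000 nM, with an expected range of 70000 nM to 300000 nM.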

Compound 3, half-maximal cytotoxic concentration: 12000 nM
For compound 3 the middle estimate is 17-fold (1.22 log units) above the measured one; measured number below the stated range.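

In this assay, among the compounds shown here, butylamino on this aromatic carbon gives the first step that can be read: an at least 16-fold lower number from compound 2 to compound 3 (1.22 log units; beyond the scatter), and an at least 16-fold lower number from compound 1 to compound 3 (1.22 log units; beyond the scatter). This group therefore lowers the tolerated concentration, so the substituent at this place can matter to this read-out. The earlier step between tert-butyl and octyloxy, like any step between two limits, cannot be read: the limit of > 200000 nM in this assay, at which 2 of the 3 values shown sit.

Butylamino differs from octyloxy in both its linking atom and its chain, so the two remain unseparated. Butoxy and octylamino at this place would separate them.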